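A Second Chloro on the Phenyl of Compound 2

The compounds below may be only part of what the source reports. "The series", "measured", "known", "first", "only" and "open" are said of these compounds alone.

In a functional assay on MCF7 cells (Homo sapiens) for antiproliferative activity, read by MTT assay, with a stated time of 72 h (a lower number here means a stronger inhibitor, a higher number a weaker inhibitor), compound 1 (`Cc1ccc(N2CCN(C(=S)SCc3ccc4nc(N)nc(N)c4c3)CC2)c(C)c1`) gives 3120 nM and compound 2 (`Nc1nc(N)c2cc(CSC(=S)N3CCN(c4ccc(Cl)cc4)CC3)ccc2n1`) gives 4880 nM as its reading, so the two values stand within the scatter of each other. Compound 3 (`Nc1nc(N)c2cc(CSC(=S)N3CCN(c4ccc(Cl)c(Cl)c4)CC3)ccc2n1`) differs from compound 2 by chloro in place of hydrogen on an aromatic carbon, ortho to a chloro group and meta to a large group, which turns 4-chlorophenyl into 3,4-dichlorophenyl. Going by the values given here, the one measured step on this phenyl, 4-chlorophenyl in place of 2,4-dimethylphenyl, is a 1.6-fold higher number from compound 1 to compound 2 (0.19 log units; within the scatter) and gives the only guide available. No step beyond the scatter is therefore expected in this assay and no firm direction can be given. For compound 3 the estimate amounts to a 1.2-fold lower number from compound 2 to compound 3 (0.09 log units; within the scatter) as the expected step. Compound 3 is expected at 4000 nM with 1800 nM to 9000 nM as the estimated range.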

Compound 3, half-maximal inhibitory concentration: 2370 nM
Beside the measured number, compound 3's estimate is 1.7-fold (0.23 log units) above it, within the range that was stated.
By their numbers in this assay, from the lowest: compounds 3, 1 and 2 (each within the scatter of the next, the first and the last beyond it).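

Chloro in place of hydrogen on this aromatic carbon, ortho to a chloro group and meta to a large group, gives the first step in the series that lies beyond the scatter in this assay, though a modest one (a 2.1-fold lower number from compound 2 to compound 3 (0.31 log units; beyond the scatter)). The turn from 4-chlorophenyl to 3,4-dichlorophenyl therefore separates compound 3 from compound 2, whereas the replacement of the 2,4-dimethylphenyl of compound 1 by 3,4-dichlorophenyl stays within the scatter (a 1.3-fold lower number from compound 1 to compound 3 (0.12 log units; within the scatter)). Nothing shown here accounts for the step from compound 2 to compound 3.

The compounds shown leave open whether a fluoro, methoxy or trifluoromethyl group on this same carbon would move the number in the same way. They also leave open whether chloro here would have any such effect without the existing chloro group.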